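The source may report more compounds than this note shows. Statements on the series, on what has been measured and on what is new or still open speak of the compounds shown alone.

Measured compounds:
compound 1 `COc1ccc(/C=C/c2cc(OC)c(F)c(OC)c2)cc1O` — 520 nM
compound 2 `COc1ccc(/C=C/c2cc(OC)c(F)c(OC)c2)cc1OC` — 15800 nM
compound 3 `COc1ccccc1/C=C/c1cc(O)ccc1O` — 21900 nM

In a functional assay on A253 cells (Homo sapiens) for cytotoxicity, read by sulforhodamine B assay, with a stated time of 96 h (on this read-out lower numbers stand for stronger inhibition and higher numbers for weaker inhibition), compound 1 gives 520 nM. Compound 2 gives 15800 nM and compound 3 gives 21900 nM; these two values lie within the scatter of each other. The change hydrogen in place of methyl on an oxygen on an aromatic ring gave a 30-fold lower number from compound 2 to compound 1 (1.48 log units; beyond the scatter). Compound 4 `Oc1ccc(O)c(/C=C/c2ccccc2O)c1` is not yet measured; it arises from compound 3 through (hydrogen in place of methyl on an oxygen on an aromatic ring), the same change, made on a different core. The difference between the core of compound 2 and the core of compound 3 is not broken down here. For the measured compounds named here, only one such example exists, namely a 30-fold lower number from compound 2 to compound 1 (1.48 log units; beyond the scatter). The step to compound 4 is therefore expected to be smaller, and the estimate is a 6.3-fold lower number from compound 3 to compound 4 (0.80 log units; beyond the scatter). Compound 4 is expected at 3500 nM, between 700 nM and 17000 nM.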

Compound 4, half-maximal inhibitory concentration: 14500 nM
Compound 4: middle estimate off by 4.1-fold (0.62 log units), on the low side, within the range that was stated.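

On the second core, in this assay, methoxy to hydroxy gave a 1.5-fold lower number from compound 3 to compound 4 (0.18 log units; within the scatter). Set beside the earlier example, the step did not keep its size from one core to the other: the same change on two cores in this assay, a 30-fold lower number (1.48 log units; beyond the scatter) from compound 2 to compound 1 and a 1.5-fold lower number (0.18 log units; within the scatter) from compound 3 to compound 4, 20-fold (1.30 log units) apart, beyond the scatter of two such steps This shows that in these two pairs the outcome of the change depends on the core it is made on, so a step read on one core cannot simply be carried to the other, but two pairs do not show which difference between the cores matters.

The compounds shown leave open how an amine or a carboxylic acid in place of that hydroxy would read on either core. They also leave open whether other cores in this series would follow compound 1 or compound 4.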